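A few compounds are considered here, and "the series" means these few. Any claim that something is new, unique, unknown or untested is made for them only; others in the source may bear on it.

Series notes, an assay on CHO cells for displacement of a labelled ligand from adenosine receptor A1 (Homo sapiens), read by scintillation counting, tested at 10 uM; a higher number here means more inhibition at the concentration tested (going by the name of the read-out), a lower number less inhibition.

Measured so far:
- compound 1: `CC(C)(C)Cc1c(-c2ccc(F)cc2F)sc(N)c1C(=O)c1ccc(Cl)cc1`, compound 1 gives 1%
- compound 2: `COc1cccc(-c2sc(N)c(C(=O)c3ccc(Cl)cc3)c2CC(C)(C)C)c1`, compound 2 gives 1%
- compound 3: `Cc1ccccc1-c1sc(N)c(C(=O)c2ccc(Cl)cc2)c1CC(C)(C)C`, compound 3 gives 1%

All three share the same core and differ only in the aryl group on the aromatic carbon of the thiophene-type ring. Compound 3 stands level with compounds 1 and 2 at the digits shown: no change at the digits printed from compound 1 to compound 3 (within the scatter) and no change at the digits printed from compound 2 to compound 3 (within the scatter), and likewise no change at the digits printed from compound 1 to compound 2 (within the scatter). Nothing in the set separates one aryl substituent from another in this assay; every value sits at the floor of the read-out.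

Compound 4 is `CC(C)(C)Cc1c(-c2ccco2)sc(N)c1C(=O)c1ccc(Cl)cc1`, not yet measured. The change from compound 3 is furan-2-yl in place of 2-methylphenyl on an aromatic carbon. The three measured steps all concern the same position and all swap one aryl group for another without any change beyond the scatter. They therefore give no indication that a further aryl swap at this position moves the read-out, although none of them involves a five-membered heteroaryl, so the step to furan-2-yl is not directly covered.

On that basis no shift beyond the scatter is expected: a number 1 percentage points higher from compound 3 to compound 4 (within the scatter) is estimated to be nil within noise. Compound 4 is estimated at 2%, with a range of -8% to 12%.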

Compound 4, a percentage reported as inhibition, at one concentration (the size of the read-out at that concentration, not a potency): 1%
The estimate for compound 4 lay 1 percentage points above the measured number, within the range that was stated.
By their numbers in this assay, from the lowest: compounds 1, 2, 3 and 4 (each within the scatter of the next).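

In this assay, the step of no change at the digits printed from compound 3 to compound 4 (within the scatter) carries the flat reading over to a five-membered aromatic ring with 1 hetero atom, and the steps of no change at the digits printed from compound 2 to compound 4 (within the scatter) and no change at the digits printed from compound 1 to compound 4 (within the scatter) show the same against the other two aryl groups. At this aromatic carbon next to the ring sulfur, neither a smaller ring nor the ring oxygen of furan-2-yl separates compound 4 from the six-membered carbon rings, which extends the earlier aryl-for-aryl comparisons beyond phenyl groups. No measured evidence accounts for this reading.

Going by these compounds, all four compounds read alike at the very bottom of the scale, so it remains open whether this position matters at all in a compound with real inhibition in this assay. Also open, on these data alone, is whether an amine or a carboxylic acid at this position, a longer chain in place of the neopentyl group, or a different group in place of the (4-chlorophenyl)carbonyl group would lift the read-out.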